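This account rests on a few compounds, and the source may have more. Where it says the series, first, only, none or still open, it means among the compounds named here.

Among the compounds with values here, in a functional assay on LNCaP cells (Homo sapiens) for antiproliferative activity (a higher number here means a weaker inhibitor, a lower number a stronger inhibitor), compound 1 `Cn1ncc(Cl)c1-c1cc(C(=O)N[C@@H]2CN[C@H](CCN3CCCCC3)C[C@H]2c2ccc(Cl)c(Cl)c2)oc1Cl` gives 1780 nM and compound 2 `Cn1ncc(Cl)c1-c1cc(C(=O)N[C@@H]2CN[C@H](CC(N)=O)C[C@H]2c2ccc(Cl)c(Cl)c2)oc1Cl` gives 160 nM, the lower of the two numbers so far. Compound 3 `Cn1ncc(Cl)c1-c1cc(C(=O)N[C@@H]2CN[C@H](CC(=O)O)C[C@H]2c2ccc(Cl)c(Cl)c2)oc1Cl` carries hydroxy in place of amino on a carbonyl carbon, which turns carbamoylmethyl into carboxymethyl: hydroxy in place of amino on a carbonyl carbon. Within the data shown here, only one measured step bears on this, and only indirectly: an 11-fold lower number from compound 1 to compound 2 (1.05 log units; beyond the scatter), a large change in the same side chain, with carbamoyl in place of (piperidin-1-yl)methyl. Among the measured compounds shown here, it shows that this chain can move the number in this assay, but no measured pair tests amino against hydroxy, so the data do not settle the direction. A moderate rise, smaller than that step, is expected, with a wide margin. The estimated shift is a 3.1-fold higher number from compound 2 to compound 3 (0.49 log units; beyond the scatter). Compound 3 is expected at 500 nM, within an estimated range of 120 nM to 2500 nM.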

Compound 3, half-maximal inhibitory concentration: 640 nM
Beside the measured number, compound 3's estimate is 1.3-fold (0.11 log units) below it; the range from low to high includes it.
By their numbers in this assay, from the lowest: compound 2; then compound 3; then compound 1.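

In this assay, the exchange on the carbonyl carbon now has a direct reading (a 4.0-fold higher number from compound 2 to compound 3 (0.60 log units; beyond the scatter)): replacing amino with hydroxy, one nitrogen for one oxygen, moves the number beyond the scatter, and carbamoylmethyl gives the lower number of this pair. Carboxymethyl also keeps a lower number than the chain bearing the piperidine ring (a 2.8-fold lower number from compound 1 to compound 3 (0.44 log units; beyond the scatter)), which places compound 3 between compound 2 and compound 1 within this side-chain set. Nothing measured here explains either step.

As far as these compounds go, how a methyl ester or a methyl amide on the same carbonyl carbon would read in this assay remains open. So does the effect of a longer chain carrying the carbamoyl group, or of a primary amine at the chain end.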